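The source may report more compounds than this note shows. Statements on the series, on what has been measured and on what is new or still open speak of the compounds shown alone.

Compound 1 `COc1ccc(/C=C/C(=O)Nc2nc3ccc([N+](=O)[O-])cc3s2)cc1O` gives 372 umol/kg in a functional assay on the whole organism (Hindlimb, strain albino) with Mus musculus as the target, in the maximal electroshock model, with a stated time of 0.5 h; on this read-out lower numbers stand for an effect already at smaller amounts and higher numbers for an effect only at larger amounts of compound.
Compound 2 `O=C(/C=C/c1ccccc1)Nc1nc2ccc([N+](=O)[O-])cc2s1` gives 485 umol/kg in this assay.
Compound 3 `O=C(/C=C/c1ccccc1)Nc1nc2ccccc2s1` gives 646 umol/kg in this assay.

Each of these three compounds holds the same amide linking a cinnamoyl-type side to a fused two-ring core, and all three numbers lie close together. Compound 2 and compound 3 differ in one place, marked hydrogen in place of nitro on an aromatic carbon: the nitro group leaves and hydrogen enters on an aromatic carbon of the six-membered ring of the core. The step that goes with it is a 1.3-fold higher number from compound 2 to compound 3 (0.12 log units; within the scatter), so within the usual scatter of such measurements no real difference between compound 2 and compound 3 can be claimed. Compound 1 and compound 2 differ in the side attached to the amide, and the difference between these two cores is not broken down here; their values sit within the scatter of one another.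

Compound 4 `COc1ccc(/C=C/C(=O)Nc2nc3ccccc3s2)cc1O` has not yet been measured. It stands to compound 1 as compound 3 stands to compound 2: the change hydrogen in place of nitro on an aromatic carbon is the same change, at a place described in the same words. Among the compounds with values here, the expectation for compound 1 to compound 4 therefore rests on the one measured example, and the step is estimated as a 1.3-fold higher number from compound 1 to compound 4 (0.12 log units; within the scatter), beside the measured 1.3-fold higher number from compound 2 to compound 3 (0.12 log units; within the scatter). Compound 4 is accordingly expected to give about 490 umol/kg, estimated to fall between 250 umol/kg and 950 umol/kg, which would keep it within the range covered by the three measured compounds.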

Compound 4, dose for half-maximal effect: 495 umol/kg
Compound 4: the middle estimate sits 1.0-fold (0.00 log units) below what was measured; the range from low to high includes it.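

In this assay, putting hydrogen in place of nitro on the core of compound 1 gives a 1.3-fold higher number from compound 1 to compound 4 (0.12 log units; within the scatter) and so, like the earlier step, it is too small to count as a real difference. This does not show that a sizeable effect would carry over from one core to another: two small steps that both lie within the scatter agree easily, and two pairs of compounds are a narrow base that says nothing about cores outside this set. What the two pairs do show is that, in this small set, removing the nitro group leaves the dose needed for an effect without a clear change on either core, and the two steps match closely: the same change on two cores in this assay, a 1.3-fold higher number (0.12 log units; within the scatter) from compound 2 to compound 3 and a 1.3-fold higher number (0.12 log units; within the scatter) from compound 1 to compound 4, 1.0-fold (0.00 log units) apart, within the scatter of two such steps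

The compounds shown carry only nitro or hydrogen at this place on the core, so it remains open whether an amine, a carboxylic acid or a chlorine atom there would move the number beyond the scatter. The side attached to the amide also appears in only two forms, which leaves open what a longer chain in that side would do to the dose needed.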